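The compounds below may be only part of what the source reports. "The series", "measured", "known", "first", "only" and "open" are said of these compounds alone.

Compound 1, `COc1ccc(S(=O)(=O)N2CCc3cccc(Nc4ccc(O)cc4)c32)cc1`: 511 nM
Compound 2, `COc1ccc(S(=O)(=O)N2CCc3cccc(Nc4ccccc4)c32)cc1`: 343 nM
Compound 3, `COc1ccc(S(=O)(=O)N2CCc3cccc(Nc4ccc(Cl)cc4)c32)cc1`: 658 nM

Of the compounds shown here, three built on one shared core have been measured in a functional assay on HT-29 cells (Homo sapiens) for antiproliferative activity; on this read-out higher numbers stand for weaker inhibition and lower numbers for stronger inhibition. Compound 1 stands second highest of the three numbers; its nearest neighbour lies at a 1.3-fold higher number from compound 1 to compound 3 (0.11 log units; within the scatter) and its furthest at a 1.5-fold lower number from compound 1 to compound 2 (0.17 log units; within the scatter), so all three sit within the scatter of one another and no order among them can be claimed.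

Compound 4, `COc1ccc(S(=O)(=O)N2CCc3cccc(Nc4ccc([N+](=O)[O-])cc4)c32)cc1`, has not yet been measured. It differs from compound 1 in one place: nitro in place of hydroxy on an aromatic carbon. Two of the measured steps bear on this exchange, as both replace the same hydroxy group of compound 1: a 1.5-fold lower number from compound 1 to compound 2 (0.17 log units; within the scatter) and a 1.3-fold higher number from compound 1 to compound 3 (0.11 log units; within the scatter). Neither replacement moved the number beyond the scatter, and the remaining step, a 1.9-fold higher number from compound 2 to compound 3 (0.28 log units; within the scatter), also stays within it. Nothing among these compounds points to a shift beyond the scatter when a nitro group takes the place of the hydroxy group, so for compound 4 a step of about a 1.1-fold higher number from compound 1 to compound 4 (0.03 log units; within the scatter) is expected. Compound 4 is therefore estimated at 550 nM, with an expected range from 250 nM to 1200 nM.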

Compound 4, half-maximal inhibitory concentration: 191 nM
For compound 4 the middle estimate is 2.9-fold (0.46 log units) above the measured one, and the stated range ends above it.
By their numbers in this assay, from the lowest: compounds 4, 2, 1 and 3 (each within the scatter of the next, the first and the last beyond it).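

In this assay, the aromatic carbon para to a large group no longer looks indifferent to what it carries. Nitro in place of hydroxy gives a 2.7-fold lower number from compound 1 to compound 4 (0.43 log units; beyond the scatter), and nitro in place of chloro gives a 3.4-fold lower number from compound 3 to compound 4 (0.54 log units; beyond the scatter); these are the first steps in the series to pass beyond the scatter, though both are modest. The step from the unsubstituted ring, a 1.8-fold lower number from compound 2 to compound 4 (0.25 log units; within the scatter), stays within the scatter, so compound 4 is set apart from compound 1 and compound 3 but not from compound 2. No measured evidence accompanies these steps, and no reason for them can be given.

The compounds shown leave open whether an amine, a carboxylic acid or a nitrile on this same carbon would fall with compound 4 and compound 2 or with compound 1 and compound 3. They also leave open whether nitro in place of hydroxy would give a step of similar size on a core other than the one shared here, or in any other cell line.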